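The source may report more compounds than this note shows. Statements on the series, on what has been measured and on what is new or still open speak of the compounds shown alone.

Among the measured compounds shown here, compound 3 `CC(=O)N1N=C(c2ccc(-n3cncn3)cc2)CC1c1ccc(N(C)C)cc1` gives -0.3% in a functional assay on NCI-H1975 cells (Homo sapiens) for inhibition, read by sulforhodamine B assay, tested at 10 uM (on this read-out lower numbers stand for less inhibition and higher numbers for more inhibition at the one concentration tested (going by the name of the read-out)), which places it second highest of the three numbers measured so far: it lies within the scatter of compound 1 `CC(=O)N1N=C(c2ccc(N3CCN(C)CC3)cc2)CC1c1ccc(N(C)C)cc1`, whose value in this assay is -1.9%, and far beyond the scatter from compound 2 `CN1CCN(c2ccc(C3=NN(S(=O)(=O)c4ccc(F)cc4)C(c4ccc(N(C)C)cc4)C3)cc2)CC1`, which reaches 95.7% in this assay. Compound 4 `Cc1ccc(S(=O)(=O)N2N=C(c3ccc(-n4cncn4)cc3)CC2c2ccc(N(C)C)cc2)cc1` differs from compound 3 by (4-methylphenyl)sulfonyl in place of acetyl on an amine nitrogen in a ring. For the measured compounds named here, the one measured step that bears on this change is the swap of (4-fluorophenyl)sulfonyl in place of acetyl on an amine nitrogen in a ring, which gave a number 97.6 percentage points higher from compound 1 to compound 2 (beyond the scatter). A rise of similar size is therefore expected, so compound 4 is estimated to reach 85% in this assay, between 55% and 100%. The expected step is a number 85.3 percentage points higher from compound 3 to compound 4 (beyond the scatter).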

Compound 4, a percentage reported as inhibition, at one concentration (the size of the read-out at that concentration, not a potency): 20%
Beside the measured number, compound 4's estimate is 65 percentage points above it, and the stated range ends above it.
By their numbers in this assay, from the lowest: compounds 1 and 3 (each within the scatter of the next); then compound 4; then compound 2.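

On the core carrying the 1H-1,2,4-triazol-1-yl group, (4-methylphenyl)sulfonyl in place of acetyl on the ring amine nitrogen also raises the number in this assay, giving a number 20.3 percentage points higher from compound 3 to compound 4 (beyond the scatter) as a modest step. Set against a number 97.6 percentage points higher from compound 1 to compound 2 (beyond the scatter) on the core carrying 4-methylpiperazin-1-yl with a (4-fluorophenyl)sulfonyl group, this shows that a sulfonyl group here does not bring a rise of one fixed size.

From the compounds shown here alone, it remains open whether the smaller rise follows from the triazolyl group or from methyl in place of fluorine on the sulfonyl ring, and what a methylsulfonyl group would give on this nitrogen. No evidence is available to explain the difference between the two steps.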